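Swapping the benzyl substituent in a bromo-indole series

The source may hold more compounds than are shown below. What is called first, only, known or untested is meant among the compounds shown, and "the series" means these compounds.

Measured so far:
- compound 1, `Cc1ccc(CO/N=C2/C(c3c[nH]c4ccc(Br)cc34)=Nc3ccc(Br)cc32)cc1`: 21400 nM
- compound 2, `Fc1ccc(CO/N=C2/C(c3c[nH]c4ccccc34)=Nc3ccccc32)cc1`: 23100 nM
- compound 3, `FC(F)(F)c1ccc(CO/N=C2/C(c3c[nH]c4ccc(Br)cc34)=Nc3ccc(Br)cc32)cc1`: 9880 nM

All three compounds were tested in a functional assay on T-24 cells (Homo sapiens) for cytotoxicity, read by MTT assay, with a stated time of 2 days; a lower number here means a stronger inhibitor, a higher number a weaker inhibitor. Among the measured compounds shown here, compound 3 gives 9880 nM, the lowest number of the three; its nearest neighbour is compound 1, and the step of a 2.2-fold lower number from compound 1 to compound 3 (0.34 log units; beyond the scatter) is the only change of a single place among the measured compounds. Compound 2 lacks the bromines of the shared core and carries a fluorine on its benzyl ring, so it differs from compound 3 in more than one place and its value can only be set beside that of compound 3.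

Compound 4, `Clc1cccc(CO/N=C2/C(c3c[nH]c4ccc(Br)cc34)=Nc3ccc(Br)cc32)c1`, has not yet been measured. Its difference from compound 3 is 3-chlorophenyl in place of 4-(trifluoromethyl)phenyl on a saturated chain carbon bound to an oxygen on an unsaturated carbon. For the measured compounds named here, no measured step involves a chlorine or a group at that position of the benzyl ring; the only step that bears on the question, a 2.2-fold lower number from compound 1 to compound 3 (0.34 log units; beyond the scatter), shows that exchanging the group on that ring moved the number by a modest amount. A 3-chlorophenyl is expected to fall between a methyl- and a trifluoromethyl-bearing ring, so for compound 4 a small rise in this assay is estimated, as a 1.5-fold higher number from compound 3 to compound 4 (0.18 log units; within the scatter), likely within the usual scatter. The estimate for compound 4 is therefore 15000 nM, with a range from 6000 nM to 35000 nM.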

Compound 4, half-maximal inhibitory concentration: 9340 nM
Estimate against measurement, compound 4: 1.6-fold (0.21 log units) above; measured number inside the range.
By their numbers in this assay, from the lowest: compounds 4 and 3 (each within the scatter of the next); then compounds 1 and 2 (each within the scatter of the next).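

In this assay, putting 3-chlorophenyl in place of 4-(trifluoromethyl)phenyl gives a 1.1-fold lower number from compound 3 to compound 4 (0.02 log units; within the scatter), so at this place on the shared core the two rings cannot be told apart, even though they differ in both the group they carry and where it sits. Compound 1 now has two single-place steps going down, a 2.2-fold lower number from compound 1 to compound 3 (0.34 log units; beyond the scatter) and a 2.3-fold lower number from compound 1 to compound 4 (0.36 log units; beyond the scatter), which shows that the earlier drop is not tied to trifluoromethyl alone, since a ring with a chlorine reaches the same level. No measurement is available that would explain why these two rings read alike or why both differ from the 4-methylphenyl ring.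

The compounds shown do not separate the effect of the chlorine from the effect of its place on the ring, as only one chlorine-bearing ring appears among them. They also leave open how this position would respond to a quite different group on the ring, such as an amine or a carboxylic acid, as every ring here carries only a methyl, a trifluoromethyl or a halogen.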